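The compounds below may be only part of what the source reports. "The series", "measured", "known", "first", "only" and "open" are said of these compounds alone.

Compound 1 `FC(F)(F)c1ccc(NCc2cn(-c3ccccc3)nc2-c2ccc(Br)cc2)cc1`, in an ADME assay on MT4 cells (Homo sapiens) for cytotoxicity, read by MTT assay, with a stated time of 96 h (on this read-out lower numbers stand for higher toxicity in this test and higher numbers for lower toxicity in this test), gives a limit of the assay, > 100000 nM.
Compound 2 `Cc1ccc(-c2nn(-c3ccccc3)cc2CNc2ccc(C(F)(F)F)cc2)cc1` gives a limit of the assay as well, > 100000 nM.
Compound 3 `Brc1ccc(NCc2cn(-c3ccccc3)nc2-c2ccc(Br)cc2)cc1` also gives a limit of the assay, > 100000 nM.

The change from compound 1 to compound 2 is methyl in place of bromo on an aromatic carbon, and its step is a step that the two limits leave unreadable from compound 1 to compound 2. The cores of compound 1 and compound 3 differ by bromo in place of trifluoromethyl on an aromatic carbon, with the step that the two limits leave unreadable from compound 1 to compound 3. Compound 4 `Cc1ccc(NCc2cn(-c3ccccc3)nc2-c2ccc(Br)cc2)cc1` differs from compound 3 by methyl in place of bromo on an aromatic carbon, the same change as from compound 1 to compound 2. For compound 4 the step that the limit leaves unreadable from compound 3 to compound 4 is expected to be unreadable too, because of the limit of > 100000 nM in this assay, at which 3 of the 3 values shown sit. Compound 4 is therefore estimated at 150000 nM, between 80000 nM and 300000 nM, most likely reported as a limit.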

Compound 4, half-maximal cytotoxic concentration: > 100000 nM
Compound 4: a limit, no number; the forecaster's own chance of this, stated with the estimate: 85%; the middle value does not contradict the limit.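

No step can be read from compound 3 or compound 1 to compound 4, as compound 4 also gives only a limit: the limit of > 100000 nM in this assay, at which 4 of the 4 values shown sit.

The compounds shown leave open whether bromo, methyl or trifluoromethyl at this place makes any difference to the read-out.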